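The source may hold more compounds than are shown below. What is called first, only, known or untested is meant among the compounds shown, and "the series" means these compounds.

Compound 1, `Cc1nc(S(C)(=O)=O)ccc1Oc1ncnc(OC2CCN(C(=O)OC(C)F)CC2)c1F`, gave 315 nM in a functional assay on isolated protein for inhibition of Glucose-dependent insulinotropic receptor (Rattus norvegicus), read by HTRF and cAMP accumulation; on this read-out lower numbers stand for an effect already at smaller amounts and higher numbers for an effect only at larger amounts of compound.
Compound 2, `Cc1nc(S(C)(=O)=O)ccc1Oc1ncnc(OC2CCN(C(=O)OC3COC3)CC2)c1F`, gave 2500 nM in this assay.
Compound 3, `Cc1nc(S(C)(=O)=O)ccc1Oc1ncnc(OC2CCN(C(=O)SC(C)(C)C)CC2)c1F`, gave 30.7 nM in this assay.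

Compound 3 stands lowest of the three numbers: compound 1 is the nearest, and the step of a 10-fold lower number from compound 1 to compound 3 (1.01 log units; beyond the scatter) lies beyond the scatter, while compound 2 is the furthest, the step of an 81-fold lower number from compound 2 to compound 3 (1.91 log units; beyond the scatter) being beyond the scatter as well. Compound 4, `Cc1nc(S(C)(=O)=O)ccc1Oc1ncnc(OC2CCN(C(=O)C(F)(F)F)CC2)c1F`, has not yet been measured in this assay. It differs from compound 3 in one place: trifluoromethyl in place of (tert-butyl)sulfanyl on a carbonyl carbon. Both steps that bear on this position point the same way. Replacing a smaller group on the carbonyl carbon by the (tert-butyl)sulfanyl group lowered the number, as seen in a 10-fold lower number from compound 1 to compound 3 (1.01 log units; beyond the scatter) and in an 81-fold lower number from compound 2 to compound 3 (1.91 log units; beyond the scatter); the step of a 7.9-fold higher number from compound 1 to compound 2 (0.90 log units; beyond the scatter) shows that among the smaller groups the numbers also differ. Since compound 4 carries a smaller group on that carbonyl carbon than compound 3 does, a higher number is expected in this assay, of a size close to the step of a 13-fold higher number from compound 3 to compound 4 (1.11 log units; beyond the scatter). For compound 4 the estimate is therefore 400 nM, with a range from 100 nM to 2000 nM.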

Compound 4, half-maximal effective concentration: 880 nM
Compound 4: middle estimate off by 2.2-fold (0.34 log units), on the low side; the range from low to high includes it.
By their numbers in this assay, from the lowest: compound 3; then compound 1; then compound 4; then compound 2.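

Trifluoromethyl is the first group in this set with no oxygen or sulfur atom on the carbonyl carbon, and in this assay it does not match the (tert-butyl)sulfanyl group, giving a 29-fold higher number from compound 3 to compound 4 (1.46 log units; beyond the scatter). It places compound 4 between the two oxygen-linked groups, with a 2.8-fold lower number from compound 2 to compound 4 (0.45 log units; beyond the scatter) on one side and a 2.8-fold higher number from compound 1 to compound 4 (0.45 log units; beyond the scatter) on the other, so the absence of that oxygen or sulfur atom does not by itself set the number at either end of the series. The last step also joins two groups of equal heavy-atom count, which shows that at this position the count alone does not fix the number.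

The data given offer no explanation for why these groups differ. From the compounds shown here alone, it also remains open whether the low number of compound 3 belongs to its sulfur or to its tert-butyl, a question that a tert-butoxy group or a dimethylamino group on the carbonyl carbon could help to settle.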